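This account rests on a few compounds, and the source may have more. Where it says the series, first, only, none or still open, it means among the compounds named here.

Measured so far:
Compound 1, `O=C1O[C@H]([C@@H](O)Cn2cc(CNS(=O)(=O)c3ccc(F)cc3)nn2)C(OCc2ccccc2)=C1OCc1ccccc1`, gives 25000 nM in a functional assay on HeLa cells (Homo sapiens) for antiproliferative activity, read by MTT assay, with a stated time of 72 h; on this read-out higher numbers stand for weaker inhibition and lower numbers for stronger inhibition.
Compound 2, `O=C1O[C@H]([C@@H](O)Cn2cc(C3CC3)nn2)C(OCc2ccccc2)=C1OCc1ccccc1`, gives 26500 nM in this assay.
Compound 3, `O=C1O[C@H]([C@@H](O)Cn2cc(CNS(=O)(=O)c3ccc(Cl)cc3)nn2)C(OCc2ccccc2)=C1OCc1ccccc1`, gives 13600 nM in this assay.

All three compounds share the same core and differ only in the group on an aromatic carbon of the five-membered ring. Compound 3 sits at the low end of the three numbers, but the steps leading to it, a 1.8-fold lower number from compound 1 to compound 3 (0.26 log units; within the scatter) and a 1.9-fold lower number from compound 2 to compound 3 (0.29 log units; within the scatter), both lie within the scatter, as does a 1.1-fold higher number from compound 1 to compound 2 (0.03 log units; within the scatter), so the three compounds cannot be told apart by these numbers.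

Compound 4, `COc1ccc(-c2cn(C[C@H](O)[C@H]3OC(=O)C(OCc4ccccc4)=C3OCc3ccccc3)nn2)cc1`, has not yet been measured. It arises from compound 3 by the change (4-methoxyphenyl in place of (((4-chlorophenyl)sulfonyl)amino)methyl on an aromatic carbon). Within the data shown here, no measured step places an aryl group directly on that ring carbon, so the closest guide is the swap of the sulfonamide-bearing group for cyclopropyl, which stayed within the scatter. On that basis no step beyond the scatter is expected in this assay, in either direction: the expected step is a 1.3-fold higher number from compound 3 to compound 4 (0.12 log units; within the scatter). Compound 4 is therefore estimated at 18000 nM, with a likely range from 6000 nM to 55000 nM.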

Compound 4, half-maximal inhibitory concentration: 16400 nM
Compound 4: middle estimate off by 1.1-fold (0.04 log units), on the high side; low and high end bracket the measured number.
By their numbers in this assay, from the lowest: compounds 3, 4, 1 and 2 (each within the scatter of the next).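

Compound 4 is the first of these compounds with an aryl group, 4-methoxyphenyl, attached directly to this ring carbon, and in this assay that change does not separate it from the others: the step is a 1.2-fold higher number from compound 3 to compound 4 (0.08 log units; within the scatter) against the chlorinated sulfonamide group and a 1.5-fold lower number from compound 1 to compound 4 (0.18 log units; within the scatter) against the fluorinated one, while against cyclopropyl it is a 1.6-fold lower number from compound 2 to compound 4 (0.21 log units; within the scatter) in a comparison with a small group. The entering group has no hydrogen-bond donor and fewer heavy atoms than the group it replaces, so among these four compounds neither the sulfonyl amino link nor its donor is needed for a number in this range. Nothing shown here gives a reason for this flat picture.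

On these data alone, all four compounds lie within the scatter of one another, so it remains open whether any group at this position can move the number beyond the scatter. An aminomethyl group, a carboxylic acid or a longer alkyl chain on this ring carbon would test that question in a way the compounds shown cannot.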